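Ester to ketone: phenyl replaces phenoxy on the carbonyl

The compounds below may be only part of what the source reports. "The series", "measured", "known", "first", "only" and "open" are said of these compounds alone.

Measured compounds:
- compound 1 `CC(/C=C/CC(C)CCCC(C)C)=C\C(=O)Oc1ccccc1`: 7.67
- compound 2 `C=CCOC(=O)/C=C(C)/C=C/CC(C)CCCC(C)(C)OC`: 5.53

Two compounds have numbers in a physicochemical assay for lipophilicity; on this read-out higher numbers stand for higher lipophilicity and lower numbers for lower lipophilicity. Compound 1 stands highest of the two; in this assay compound 1 gives 7.67, and compound 2 gives 5.53, a gap that lies beyond the scatter. Among the compounds with values here, no pair of measured compounds differs in just one place, so no measured step is available.

Compound 3 `CC(/C=C/CC(C)CCCC(C)C)=C\C(=O)c1ccccc1` is not yet measured. It differs from compound 1 in one place: phenyl in place of phenoxy on a carbonyl carbon. The phenoxy group on the carbonyl carbon is replaced by phenyl, so the ester becomes a ketone.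

Within the data shown here, with no measured step to lean on, a small change is expected, not clearly beyond the scatter, with the number for compound 3 perhaps slightly higher than for compound 1. The expected step from compound 1 to compound 3 is a number 0.08 log units higher from compound 1 to compound 3 (within the scatter). For compound 3 the estimate in this assay is 7.75, with a range from 7.3 to 8.2.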

Compound 3, partition coefficient: 7.26
Compound 3: the middle estimate sits 0.49 log units above what was measured; the measured number lies below the stated range.
By their numbers in this assay, from the lowest: compound 2; then compound 3; then compound 1.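

In this assay, within the data shown here, putting phenyl in place of phenoxy on a carbonyl carbon, which turns the ester into a ketone, gives a number 0.41 log units lower from compound 1 to compound 3 (beyond the scatter) and so supplies the first measured step at this position. It shows that the group on this carbonyl carbon can move the read-out while the rest of the molecule stays the same. A six-membered aromatic ring of carbon only stands on both sides of the step, so the difference lies in the oxygen of phenoxy and the change from ester to ketone, although nothing at hand explains why the number moves in this direction.

The compounds shown leave open how an amine or a longer chain on this carbonyl carbon would compare. They also leave open whether the same change would give a step of similar size on the core of compound 2 .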